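The source may report more compounds than this note shows. Statements on the series, on what has been measured and on what is new or still open speak of the compounds shown alone.

Three compounds sharing one core have been characterised so far. Compound 1 `CCOC(=O)c1cccc(-c2ccc(O)cc2)c1` gives, in an assay on COS-7 cells for inhibition of patatin-like phospholipase domain-containing protein 2 (Mus musculus) (on this read-out higher numbers stand for weaker inhibition and lower numbers for stronger inhibition), a value of 100000 nM. Compound 2 `CCOC(=O)c1cccc(-c2ccc(C)cc2)c1` gives 140000 nM in this assay, and compound 3 `CCOC(=O)c1cccc(-c2ccc(CN3CCCCC3)cc2)c1` gives 75000 nM. Compound 3 has the lowest number of the three, but the steps to it, a 1.3-fold lower number from compound 1 to compound 3 (0.12 log units; within the scatter) and a 1.9-fold lower number from compound 2 to compound 3 (0.27 log units; within the scatter), both fall within the scatter, so the three compounds cannot be told apart on these numbers; the same holds for a 1.4-fold higher number from compound 1 to compound 2 (0.15 log units; within the scatter).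

Compound 4 `CCOC(=O)c1cccc(-c2ccc(C(C)N(C)C)cc2)c1` has not yet been measured. It differs from compound 3 in one place: 1-(dimethylamino)ethyl in place of (piperidin-1-yl)methyl on an aromatic carbon. The measured steps that bear on this change are those that alter the same position on the ring, above all the step in which the piperidin-1-yl was added onto the methyl, and neither of them moved the number beyond the scatter. Exchanging one amine-bearing substituent for another at this position is therefore expected to leave the value roughly where compound 3 sits, with no step beyond the scatter, as an expectation of no change at the digits printed from compound 3 to compound 4 (within the scatter). For compound 4 the estimate in this assay is 75000 nM, expected to lie between 35000 nM and 160000 nM.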

Compound 4, half-maximal inhibitory concentration: 200000 nM
Estimate against measurement, compound 4: 2.7-fold (0.43 log units) below; measured number outside the range, above it.
By their numbers in this assay, from the lowest: compounds 3, 1, 2 and 4 (each within the scatter of the next, the first and the last beyond it).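

In this assay the exchange of (piperidin-1-yl)methyl for 1-(dimethylamino)ethyl gives a 2.7-fold higher number from compound 3 to compound 4 (0.43 log units; beyond the scatter), the only step among these compounds that passes the scatter, so two amine-bearing groups at this position need not behave alike. The new group still cannot be told apart from the smaller substituents: a 1.4-fold higher number from compound 2 to compound 4 (0.15 log units; within the scatter) and a 2.0-fold higher number from compound 1 to compound 4 (0.30 log units; within the scatter) both stay within the scatter, which means the difference appears only between the two ends of the series, compound 3 and compound 4. No measurement is available that would account for this step.

The compounds shown leave open which part of the exchange carries the step, the loss of the piperidine ring or the extra methyl on the chain carbon bound to the aromatic ring, and a (dimethylamino)methyl group or a 1-(piperidin-1-yl)ethyl group would separate the two. Also open, from the compounds shown here alone, is whether any other group at this position, such as a carboxylic acid or a longer amine chain, would bring the number clearly below that of compound 3.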